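A few compounds are considered here, and "the series" means these few. Any claim that something is new, unique, unknown or untested is made for them only; others in the source may bear on it.

Within the data shown here, compound 1 `FC(F)(F)c1cccc(N2CCN(c3ccc(-c4ncns4)nn3)CC2)c1` stands highest of the two numbers so far in a functional assay (aorta) for inhibition, with Rattus norvegicus as the target (on this read-out higher numbers stand for weaker inhibition and lower numbers for stronger inhibition), where compound 1 gives 70 nM. Among the measured compounds shown here, its only neighbour, compound 2 `Nc1nsc(-c2ccc(N3CCN(c4cccc(C(F)(F)F)c4)CC3)nn2)n1`, gives 20 nM in this assay, and the single measured step is a 3.5-fold lower number from compound 1 to compound 2 (0.54 log units; beyond the scatter). Compound 3 `FC(F)(F)c1cc(N2CCN(c3ccc(-c4ncns4)nn3)CC2)cc(C(F)(F)F)c1` differs from compound 1 by trifluoromethyl in place of hydrogen on an aromatic carbon. For the measured compounds named here, the one known step concerns an amino group and does not bear on a second trifluoromethyl, so no direction can be drawn from it. Compound 3 is therefore expected to give 70 nM, within 25 nM to 200 nM. This expected estimate means a step of no change at the digits printed from compound 1 to compound 3 (within the scatter), none beyond the scatter.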

Compound 3, half-maximal inhibitory concentration: < 1 nM
Compound 3 gave a limit, no number (the forecaster's own chance of this, stated with the estimate: 5%); middle value at least 70-fold (1.84 log units) away from the limit.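

The earlier compounds shown here left this carbon of the six-membered aromatic ring unchanged, and it now proves highly responsive: trifluoromethyl in place of hydrogen there gives an at least 70-fold lower number from compound 1 to compound 3 (1.84 log units; beyond the scatter) in this assay. The value of compound 3 is a limit and not a number, so the full size of this step cannot be read: the limit of < 1 nM in this assay, at which 1 of the 3 values shown sits.

On these data alone, it remains open whether a methyl, a chlorine or a methoxy group at this place would give a step of similar size. Also open, as far as these compounds go, is how the amino group of compound 2 would combine with this second trifluoromethyl.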